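This account rests on a few compounds, and the source may have more. Where it says the series, first, only, none or still open, it means among the compounds named here.

Measured in a functional assay on HCC 2998 cells (Homo sapiens) for antiproliferative activity; on this read-out lower numbers stand for stronger inhibition of growth and higher numbers for weaker inhibition of growth:
- Compound 1 `COc1ccc(-c2nc3cc(F)ccc3s2)cc1`: 12400 nM
- Compound 2 `COc1ccc(-c2nc3cc(F)ccc3s2)cc1F`: 13700 nM
- Compound 3 `COc1ccc(-c2nc3cc(F)ccc3s2)cc1OC`: 0.25 nM

Compound 3, at 0.25 nM, has the lowest number of the three, and so is the strongest inhibitor of growth here. Its gaps to both other compounds lie far beyond the scatter.

The next compound is compound 4 `COCOc1ccc(-c2nc3cc(F)ccc3s2)cc1OC`. It puts a methoxy in place of hydrogen on a saturated chain carbon bound to an oxygen on an aromatic ring, turning a methoxy into a methoxymethoxy: methoxy in place of hydrogen on a saturated chain carbon bound to an oxygen on an aromatic ring.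

Going by the values given here, no measured step makes this exact change. The nearest evidence concerns a methoxy added on an aromatic carbon, which gave a 50000-fold lower number from compound 1 to compound 3 (4.70 log units; beyond the scatter). Replacing fluoro with methoxy gave a 55000-fold lower number from compound 2 to compound 3 (4.74 log units; beyond the scatter), while fluoro in place of hydrogen gave only a 1.1-fold higher number from compound 1 to compound 2 (0.04 log units; within the scatter). Such steep steps show that the high activity of compound 3 depends strongly on small changes to this part of the molecule, so some loss seems likely, though its size is poorly defined.

The expected step is a 120-fold higher number from compound 3 to compound 4 (2.08 log units; beyond the scatter), towards weaker inhibition of growth. Compound 4 is estimated at 30 nM, with an expected range of 0.3 nM to 5000 nM.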

Compound 4, concentration for 50% growth inhibition: 53500 nM
Estimate against measurement, compound 4: 1800-fold (3.25 log units) below, and the stated range ends below it.
By their numbers in this assay, from the lowest: compound 3; then compounds 1 and 2 (each within the scatter of the next); then compound 4.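

In this assay, the step to the methoxymethoxy group gave a 210000-fold higher number from compound 3 to compound 4 (5.33 log units; beyond the scatter), which shows that the high activity of compound 3 also depends sharply on the methoxy group itself, not only on what sits on the aromatic carbons. The same entering group, methoxy, had the opposite outcome in a 50000-fold lower number from compound 1 to compound 3 (4.70 log units; beyond the scatter), so in these compounds its effect depends entirely on where it is placed. Nothing available here explains why adding just 2 heavy atoms has so large an effect.

The compounds shown leave open whether any other group can stand in this place without the same loss. A hydroxyl, an ethoxy or a longer alkoxy chain there would show whether the added oxygen or the longer chain goes with the drop.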